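The compounds below may be only part of what the source reports. "The series", "measured", "known", "first", "only" and "open" are said of these compounds alone.

Compound 1 `O=C(CSc1nnnn1-c1cccc2ccccc12)N/N=C/c1ccccc1Cl`: in an ADME assay on MT4 cells (Homo sapiens) for cytotoxicity, read by MTT assay (on this read-out lower numbers stand for higher toxicity in this test and higher numbers for lower toxicity in this test), compound 1 gives 69700 nM.
Compound 2 `O=C(CSc1nnnn1-c1cccc2ccccc12)N/N=C/c1ccc([N+](=O)[O-])cc1`: in this assay compound 2 gives >= 260000 nM, which is a limit of the assay.
Compound 3 `COc1cc(/C=N/NC(=O)CSc2nnnn2-c2cccc3ccccc23)ccc1O`: in this assay compound 3 gives > 287000 nM, which is also a limit of the assay.

Compound 3 therefore stands at a limit rather than at a number, and the same holds for one further value, so that of the three values shown only compound 1 has a read number; the limits are the limit of > 287000 nM in this assay, at which 1 of the 3 values shown sits, and (the limit of >= 260000 nM in this assay, at which 1 of the 3 values shown sits). Compound 4 `O=C(CSc1nnnn1-c1cccc2ccccc12)N/N=C/c1ccccc1` differs from compound 3 in one place: phenyl in place of 4-hydroxy-3-methoxyphenyl on a carbon with a double bond to nitrogen. For the measured compounds named here, only one measured step bears directly on this change, the step of an at least 4.1-fold higher number from compound 1 to compound 3 (0.61 log units; beyond the scatter), in which the 4-hydroxy-3-methoxyphenyl group replaced 2-chlorophenyl. The step of an at least 3.7-fold higher number from compound 1 to compound 2 (0.57 log units; beyond the scatter) shows a similar direction for a different group, while a step that the two limits leave unreadable from compound 2 to compound 3 cannot be read. Removing the hydroxy and methoxy groups is expected to move compound 4 back toward compound 1, so a step downward of about an at least 1.9-fold lower number from compound 3 to compound 4 (0.28 log units; that floor lies within the scatter) is expected, though the limit at compound 3 makes its true size uncertain. Compound 4 is estimated at 150000 nM, in a range from 60000 nM to 300000 nM.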

Compound 4, half-maximal cytotoxic concentration: 216000 nM
Estimate against measurement, compound 4: 1.4-fold (0.16 log units) below, within the range that was stated.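

Hydrogen in place of chloro on an aromatic carbon gives a 3.1-fold higher number from compound 1 to compound 4 (0.49 log units; beyond the scatter) in this assay, so plain phenyl at this position already stands clear of the 2-chlorophenyl of compound 1, with no added group needed. Phenyl in place of 4-hydroxy-3-methoxyphenyl gives an at least 1.3-fold lower number from compound 3 to compound 4 (0.12 log units; that floor lies within the scatter), and hydrogen in place of nitro gives an at least 1.2-fold lower number from compound 2 to compound 4 (0.08 log units; that floor lies within the scatter); both floors lie within the scatter, so neither step shows that those groups raise the number over phenyl. Compound 3 stands at a limit of the assay, so the true size of its step stays unread: the limit of > 287000 nM in this assay, at which 1 of the 4 values shown sits.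

Going by these compounds, the step between compound 2 and compound 3 cannot be read, so their order stays open. Also open, on these data alone, is how an amine or a carboxylic acid on the phenyl would read here.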